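Removing the Cyclohexyloxy Group from an Acylguanidine Series

This account rests on a few compounds, and the source may have more. Where it says the series, first, only, none or still open, it means among the compounds named here.

Measured in a functional assay for inhibition of sodium/hydrogen exchanger (Oryctolagus cuniculus); on this read-out lower numbers stand for stronger inhibition and higher numbers for weaker inhibition:
- compound 1 `CCc1cc(C)c(C(=O)N=C(N)N)cc1S(C)(=O)=O`: 4.8 nM
- compound 2 `CSc1cc(C)c(C(=O)N=C(N)N)cc1S(C)(=O)=O`: 6 nM
- compound 3 `Cc1cc(OC2CCCCC2)c(S(C)(=O)=O)cc1C(=O)N=C(N)N`: 37 nM

Compound 3 stands highest of the three numbers, and the two steps that reach it are both beyond the scatter: a 7.7-fold higher number from compound 1 to compound 3 (0.89 log units; beyond the scatter) and a 6.2-fold higher number from compound 2 to compound 3 (0.79 log units; beyond the scatter); compound 1 and compound 2 differ only within the scatter a 1.3-fold higher number from compound 1 to compound 2 (0.10 log units; within the scatter). Compound 4 `Cc1ccc(S(C)(=O)=O)cc1C(=O)N=C(N)N` is not yet measured. It differs from compound 3 by one change (hydrogen in place of cyclohexyloxy on an aromatic carbon). Both measured steps that bear on this place show that cyclohexyloxy gives a higher number than a small group, so its removal is expected to lower the number in this assay, though nothing measured here shows what a bare hydrogen at that place does. Compound 4 is therefore estimated at 14 nM, within 4 nM to 50 nM, an expected step of a 2.6-fold lower number from compound 3 to compound 4 (0.42 log units; beyond the scatter).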

Compound 4, half-maximal inhibitory concentration: 150 nM
Compound 4: the middle estimate sits 11-fold (1.03 log units) below what was measured; measured number outside the range, above it.
By their numbers in this assay, from the lowest: compounds 1 and 2 (each within the scatter of the next); then compound 3; then compound 4.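

In this assay, a bare hydrogen on this aromatic carbon, ortho to a methylsulfonyl group, turns out poorer than cyclohexyloxy, so the large group was doing better than nothing (a 4.1-fold higher number from compound 3 to compound 4 (0.61 log units; beyond the scatter)). The loss is larger still against methylsulfanyl (a 25-fold higher number from compound 2 to compound 4 (1.40 log units; beyond the scatter)) and ethyl (a 31-fold higher number from compound 1 to compound 4 (1.49 log units; beyond the scatter)), so all three groups shown give lower numbers than hydrogen. Nothing available here accounts for these gaps. The compounds shown leave open whether an amine or a carboxylic acid at this place would reach the numbers of ethyl and methylsulfanyl, and where a propyl chain would fall.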